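Relocating the methyl on the terminal phenyl of compound 3

This account rests on a few compounds, and the source may have more. Where it says the series, first, only, none or still open, it means among the compounds named here.

Compound 1 `COC(=O)/C=C/c1cccc(N(Cc2ccc(/C=C/c3scnc3C)cc2)C(=O)C(C)C)c1` gives 228 nM in an assay on isolated protein with Bile acid receptor (Homo sapiens) as the target; on this read-out higher numbers stand for an effect only at larger amounts of compound and lower numbers for an effect already at smaller amounts.
Compound 2 `COC(=O)/C=C/c1cccc(N(Cc2ccc(-c3ccc(C)cc3)cc2)C(=O)C(C)C)c1` gives 118 nM in this assay.
Compound 3 `COC(=O)/C=C/c1cccc(N(Cc2ccc(-c3ccc(C)cc3)cc2)C(=O)NC(C)C)c1` gives 449 nM in this assay.

Compound 3 carries the highest of the three numbers; its value and that of compound 1 lie within the scatter of each other, while a 3.8-fold higher number from compound 2 to compound 3 (0.58 log units; beyond the scatter) separates it from compound 2.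

Compound 4 `COC(=O)/C=C/c1cccc(N(Cc2ccc(-c3cccc(C)c3)cc2)C(=O)NC(C)C)c1` differs from compound 3 by 3-methylphenyl in place of 4-methylphenyl on an aromatic carbon. For the measured compounds named here, no measured step moves a methyl on this ring. Going by the values given here, the only change at this position, a 1.9-fold lower number from compound 1 to compound 2 (0.29 log units; within the scatter), replaced the whole group and stayed within the scatter, and a 3.8-fold higher number from compound 2 to compound 3 (0.58 log units; beyond the scatter) concerns the carbonyl substituent instead. Compound 4 is therefore expected to give 450 nM, with a range from 180 nM to 1100 nM. The expected step is a 1.0-fold higher number from compound 3 to compound 4 (0.00 log units; within the scatter).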

Compound 4, half-maximal effective concentration: 1330 nM
For compound 4 the middle estimate is 3.0-fold (0.47 log units) below the measured one, outside the stated range (above it).
By their numbers in this assay, from the lowest: compounds 2, 1 and 3 (each within the scatter of the next, the first and the last beyond it); then compound 4.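

In this assay, moving the methyl alone on the terminal ring, with the same atoms and no change in the counted features, gives a 3.0-fold higher number from compound 3 to compound 4 (0.47 log units; beyond the scatter). The earlier compounds shown here showed only a whole-group swap at this position that stayed within the scatter; here the placement of one methyl is enough to go beyond it. Nothing available explains this shift.

On these data alone, it remains open whether a phenyl without the methyl, or a methoxy group in its place, would follow compound 3 or compound 4. As far as these compounds go, it is also open whether the shift would recur with the isopropyl on the carbonyl carbon, as in compound 2.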